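A few compounds are considered here, and "the series" means these few. Any claim that something is new, unique, unknown or untested is made for them only; others in the source may bear on it.

Compound 1, `COC(=O)N[C@H](C(=O)N1CCC[C@H]1C(=O)Nc1ccc([C@@H]2CC[C@@H](c3ccc(NC(=O)[C@@H]4CCCN4C(=O)[C@@H](NC(=O)OC)[C@@H](C)OC)cc3)N2c2ccc(F)cc2)cc1)[C@@H](C)OC`, and compound 2, `COC(=O)N[C@H](C(=O)N1CCC[C@H]1C(=O)Nc1ccc([C@@H]2CC[C@@H](c3ccc(NC(=O)[C@@H]4CCCN4C(=O)[C@@H](NC(=O)OC)C(C)(C)C)cc3)N2c2ccc(F)cc2)cc1)C(C)(C)C`, were both tested in an ADME assay on the whole organism (plasma) for pharmacokinetics, with Rattus norvegicus as the target, at a dose of 3 mg/kg by the oral route; on this read-out lower numbers stand for lower exposure and higher numbers for higher exposure at the dose given. In this assay compound 1 gives 120 ng.h/mL, while compound 2 gives 1850 ng.h/mL, the higher of the two numbers and a gap beyond the usual scatter. Compound 3, `COC(=O)N[C@H](C(=O)N1CCC[C@H]1C(=O)Nc1ccc([C@H]2CC[C@H](c3ccc(NC(=O)[C@@H]4CCCN4C(=O)[C@@H](NC(=O)OC)C(C)(C)C)cc3)N2c2ccc(F)cc2)cc1)C(C)(C)C`, has not yet been measured. It is related to compound 2 as follows: the two compounds have the same atoms and bonds and differ only in configuration as drawn: 2 of 6 stereo elements differ; a stereocentre at a saturated ring carbon is drawn S in compound 2 and R in compound 3; a stereocentre at a saturated ring carbon is drawn S in compound 2 and R in compound 3. Within the data shown here, no measured pair shows what such a change does here, so the step is expected to be modest, probably toward lower exposure yet possibly within the scatter, as a 2.1-fold lower number from compound 2 to compound 3 (0.31 log units; beyond the scatter). Compound 3 is therefore estimated at 900 ng.h/mL, within a range from 200 ng.h/mL to 3000 ng.h/mL.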

Compound 3, area under the concentration-time curve in the Rattus norvegicus assay: 10200 ng.h/mL
The estimate for compound 3 lay 11-fold (1.05 log units) below the measured number; measured number above the stated range.
By their numbers in the Rattus norvegicus assay, from the lowest: compound 1; then compound 2; then compound 3.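

In the Rattus norvegicus assay, inverting the two stereocentres at saturated ring carbons gives a 5.5-fold higher number from compound 2 to compound 3 (0.74 log units; beyond the scatter), so the drawn configuration at these carbons matters for exposure, something compounds 1 and 2 could not show. In a physicochemical assay for lipophilicity, read by HPLC, at pH 7.4 (on this read-out higher numbers stand for higher lipophilicity and lower numbers for lower lipophilicity), compound 2 gives 5.2 and compound 3 gives 5.2, the same number. The gap in exposure therefore goes with configuration alone: the fact that compounds 2 and 3 differ only in the configuration as drawn.

Still open, as far as these compounds go, is what inverting only one of these stereocentres would do, or the same inversion with the side chains of compound 1. Also open, from the compounds shown here alone, is whether this configuration holds its exposure with a nitrile in place of the fluorine.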